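A few compounds are considered here, and "the series" means these few. Any claim that something is new, unique, unknown or untested is made for them only; others in the source may bear on it.

Measured so far in a functional assay on DU-145 cells (Homo sapiens) for inhibition, read by trypan blue exclusion, with a stated time of 96 h; on this read-out lower numbers stand for stronger inhibition of growth and higher numbers for weaker inhibition of growth:
- compound 1, `Cc1ccc(CS/C(=C/c2ccccc2F)C(=O)c2ccc(Cl)cc2)cc1`: 10000 nM
- compound 2, `Cc1ccc(CS/C(=C/c2ccc(Br)cc2)C(=O)c2ccc(Cl)cc2)cc1`: 10000 nM
- compound 3, `Cc1ccc(S/C(=C/c2c[nH]c3ccc(Br)cc23)C(=O)c2ccc(Cl)cc2)cc1`: 1000 nM

Compound 3 gives the lowest number of the three; the values of compound 1 and compound 2 both lie higher, and both gaps are beyond the scatter. Within the data shown here, the only single-point step among the measured compounds is no change at the digits printed from compound 1 to compound 2 (within the scatter), and it touches the group on the double-bonded chain carbon, not the sulfur.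

Compound 4, `Cc1ccc(CS/C(=C/c2c[nH]c3ccc(Br)cc23)C(=O)c2ccc(Cl)cc2)cc1`, has not yet been measured in this assay. It differs from compound 3 by 4-methylbenzyl in place of 4-methylphenyl on a sulfur. Among the measured compounds shown here, no measured pair isolates this change: compound 1 and compound 2 carry the 4-methylbenzyl on sulfur and compound 3 carries the 4-methylphenyl, but those pairs also differ on the double-bonded chain carbon, so the two changes cannot be separated on the present numbers.

The expectation for compound 4 therefore rests mainly on compound 3, whose value 1000 nM is the starting point, with some allowance for a weaker result given that both compounds with the 4-methylbenzyl on sulfur sit higher. The step expected from compound 3 to compound 4 is a 2.0-fold higher number from compound 3 to compound 4 (0.30 log units; within the scatter). Compound 4 is estimated at 2000 nM, with a range from 700 nM to 8000 nM.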

Compound 4, concentration for 50% growth inhibition: 1000 nM
For compound 4 the middle estimate is 2.0-fold (0.30 log units) above the measured one, within the range that was stated.
By their numbers in this assay, from the lowest: compounds 3 and 4 (each within the scatter of the next); then compounds 1 and 2 (each within the scatter of the next).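

In this assay, the change from 4-methylphenyl to 4-methylbenzyl on the sulfur can now be read on its own, with the 5-bromo-1H-indol-3-yl group held constant, and it gives no change at the digits printed from compound 3 to compound 4 (within the scatter). With 4-methylbenzyl held constant on the sulfur, the group on the double-bonded chain carbon does produce a difference: 5-bromo-1H-indol-3-yl in place of 4-bromophenyl gives a 10-fold lower number from compound 2 to compound 4 (1.00 log units; beyond the scatter), and in place of 2-fluorophenyl it gives a 10-fold lower number from compound 1 to compound 4 (1.00 log units; beyond the scatter). No measurement in hand offers an explanation for either finding.

Whether the sulfur change is equally silent with 4-bromophenyl or 2-fluorophenyl on the chain carbon remains open, as the compounds shown contain no such pair. Going by these compounds, it is also open whether a longer chain such as 2-phenylethyl, or a chain ending in an amine, on the sulfur would stay level with compound 4 at 1000 nM, and whether the bromine of the 5-bromo-1H-indol-3-yl group is needed for the lower numbers.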